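The compounds below may be only part of what the source reports. "The series", "measured", "known", "first", "only" and "open" are said of these compounds alone.

Measured so far in a functional assay on SW-620 cells (Homo sapiens) for inhibition, read by sulforhodamine B assay, with a stated time of 48 h; on this read-out lower numbers stand for higher toxicity in this test and higher numbers for lower toxicity in this test:
Compound 1 `COc1cc(-c2nn(-c3cccc(NC(=O)c4cccc(C(F)(F)F)c4)c3)cc2-c2ccncc2)ccc1Cl` gives a limit of the assay, > 50000 nM, and no number.
Compound 2 `O=C(Nc1cccc(-n2cc(-c3ccncc3)c(-c3ccc(Cl)c(O)c3)n2)c1)Nc1cc(C(F)(F)F)cc(C(F)(F)F)c1` gives 23400 nM.
Compound 3 `O=C(Nc1cccc(-n2cc(-c3ccncc3)c(-c3ccc(Cl)c(O)c3)n2)c1)Nc1ccc(Cl)c(C(F)(F)F)c1` gives a limit of the assay, > 32500 nM.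

Compound 1 therefore stands at the upper edge of what this assay reports, (the limit of > 50000 nM in this assay, at which 1 of the 3 values shown sits); a second limit sits lower, (the limit of > 32500 nM in this assay, at which 1 of the 3 values shown sits). Only compound 2 gives a number, and it sits in the weak range.

Compound 4 `COc1cc(-c2nn(-c3cccc(NC(=O)Nc4ccc(Cl)c(Cl)c4)c3)cc2-c2ccncc2)ccc1Cl` is not yet measured. It differs from compound 1 by (3,4-dichlorophenyl)amino in place of 3-(trifluoromethyl)phenyl on a carbonyl carbon. Within the data shown here, no measured pair shows this change, so its size is unknown; the urea compounds 2 and 3 both sit at weak values. The step from compound 1 to compound 4 is expected to be small, an at least 1.4-fold lower number from compound 1 to compound 4 (0.15 log units; that floor lies within the scatter), possibly none beyond the scatter. Compound 4 is expected near 35000 nM, between 12000 nM and 100000 nM, with a real chance that this assay again reports only a limit.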

Compound 4, concentration lethal to 50% of the cells: > 50000 nM
Compound 4 gave a limit, no number; the forecaster's own chance of this, stated with the estimate: 55%; middle value at least 1.4-fold (0.15 log units) away from the limit.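

In this assay, among these compounds, compound 1 and compound 4 each give only a limit of the assay, so no step between them can be read. From the compounds shown here alone, whether (3,4-dichlorophenyl)amino in place of 3-(trifluoromethyl)phenyl on a carbonyl carbon changes the read-out at all stays open.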